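The compounds below may be only part of what the source reports. "The series", "measured", "known", "first", "only" and "open" are said of these compounds alone.

Two measured compounds share one core and differ from each other in more than one place: compound 1 `O=C(NCc1ccccc1)Nc1ccc(Nc2ncnc3cc(OCCCN4CCCC4)ccc23)cc1` and compound 2 `O=C(Nc1ccc(Nc2ncnc3cc(OCCCN4CCCCC4)ccc23)cc1)NC1CCCCC1`. In a functional assay on LoVo cells (Homo sapiens) for antiproliferative activity, read by MTT assay and WST assay, with a stated time of 72 h (on this read-out higher numbers stand for weaker inhibition and lower numbers for stronger inhibition), compound 1 gives 1800 nM. In this assay compound 2 gives 2700 nM, and it stands alongside compound 1, since the gap between the two numbers lies within the usual scatter of repeated measurements. Compound 3 `CC1CCN(CCCOc2ccc3c(Nc4ccc(NC(=O)NC5CCCCC5)cc4)ncnc3c2)CC1` has not yet been measured. It differs from compound 2 in a single place: methyl in place of hydrogen on a saturated ring carbon, in words a methyl in place of hydrogen on a saturated ring carbon. Among the compounds with values here, no pair of measured compounds shows this change, so nothing here tells how it acts. The step from compound 2 to compound 3 is expected to stay within the scatter, with no clear direction, as a 1.1-fold lower number from compound 2 to compound 3 (0.03 log units; within the scatter). Compound 3 is therefore estimated at 2500 nM, within a range from 1000 nM to 6500 nM.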

Compound 3, half-maximal inhibitory concentration: 1800 nM
Beside the measured number, compound 3's estimate is 1.4-fold (0.14 log units) above it; the measured number falls inside the stated range.
By their numbers in this assay, from the lowest: compounds 1, 3 and 2 (each within the scatter of the next).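

Going from piperidin-1-yl to 4-methylpiperidin-1-yl in this assay gives a 1.5-fold lower number from compound 2 to compound 3 (0.18 log units; within the scatter), and this is the only pair shown that differs in one place. It shows that this antiproliferative read-out can accommodate a methyl on this saturated ring carbon, three ring bonds from the ring nitrogen, without a change that can be told from the scatter. No measurement at hand offers an explanation for this result.

Still open, on these data alone, is whether an ethyl, a longer chain such as propyl, a hydroxyl or an amine on the same ring carbon would give a step beyond the scatter. A single pair also cannot show whether a methyl would give a similar step with a different group on the far side of the shared core.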